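The source may report more compounds than this note shows. Statements on the series, on what has been measured and on what is new or still open speak of the compounds shown alone.

Working notes on the series. Compound 1 `COc1cc2c(cc1OC)CN(CCCC(=O)c1c(C)c(OC)c(OC)c(OC)c1OC)CC2` is the shortest-chain member. In an assay on membranes from brain for displacement of a labelled ligand from Sigma non-opioid intracellular receptor 1 (Cavia porcellus), read by scintillation counting, with a stated time of 120 min (on this read-out lower numbers stand for stronger inhibition and higher numbers for weaker inhibition), compound 1 gives no number but only a limit, > 1000 nM. Compound 2 `COc1cc2c(cc1OC)CN(CCCCCCC(=O)c1c(C)c(OC)c(OC)c(OC)c1OC)CC2` carries the longer chain on the same core. In this assay compound 2 likewise gives only a limit, > 1000 nM. Compound 3 `COc1cc2c(c(OC)c1OC)CCN(CCCCCCC(=O)c1c(C)c(OC)c(OC)c(OC)c1OC)C2` adds a methoxy group on the core of compound 2. In this assay compound 3 again gives only a limit, > 1000 nM. The step that the two limits leave unreadable from compound 2 to compound 3 cannot be sized because the limit of > 1000 nM in this assay, at which 3 of the 3 values shown sit, holds for both ends of it.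

Compound 4 `COc1cc2c(c(OC)c1OC)CN(CCCCCCC(=O)c1c(C)c(OC)c(OC)c(OC)c1OC)CC2` also derives from compound 2 by methoxy in place of hydrogen on an aromatic carbon. Among the measured compounds shown here, the only measured step bearing on this change is a step that the two limits leave unreadable from compound 2 to compound 3, and its size is not readable. Compound 2 stands at the limit in this assay, with no number behind it, so neither a direction nor a size beyond the scatter can be expected for the step from compound 2 to compound 4; the estimated step is a step that the limit leaves unreadable from compound 2 to compound 4. Compound 4 is therefore expected to sit at about 3000 nM, within a range from 1000 nM to 20000 nM, most likely reported again only as a limit.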

Compound 4, inhibition constant: > 1000 nM
Compound 4 ended at the assay's limit; the forecaster's own chance of this, stated with the estimate: 85%; the middle value is on the limit's open side.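

No new step can be read between compound 2 and compound 4, as both ends remain limits: the limit of > 1000 nM in this assay, at which 4 of the 4 values shown sit.

The compounds shown leave open whether chain length or a methoxy group on the core changes the inhibition constant at all in this assay.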